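Dimethylamino to diethylamino swap on the amide side chain

The source may hold more compounds than are shown below. What is called first, only, known or untested is meant among the compounds shown, and "the series" means these compounds.

Compound 2 `CCn1c(C(=O)NCCN(C)C)ccc1C(CC)(CC)c1ccc(OCC(=O)C(C)(C)C)c(C)c1` gives 520 nM in a functional assay on MCF7 cells (Homo sapiens), read by MTT assay, with a stated time of 48 h; a lower number here means a stronger inhibitor, a higher number a weaker inhibitor. Compound 1 `CCN(CC)CCNC(=O)c1ccc(C(CC)(CC)c2ccc(OCC(=O)C(C)(C)C)c(C)c2)n1CC` differs by diethylamino in place of dimethylamino on a saturated chain carbon, two bonds along the chain from an amide-type nitrogen and gives 690 nM in this assay, so that step reads a 1.3-fold higher number from compound 2 to compound 1 (0.12 log units; within the scatter). Compound 3 `CCn1c(C(=O)NCCCN(C)C)ccc1C(CC)(CC)c1ccc(OCC(O)C(C)(C)C)c(C)c1` gives 490 nM in this assay; how compound 3 differs from compound 2 is not broken down here. Compound 4 `CCN(CC)CCCNC(=O)c1ccc(C(CC)(CC)c2ccc(OCC(O)C(C)(C)C)c(C)c2)n1CC`, not yet measured, differs from compound 3 by diethylamino in place of dimethylamino on a saturated chain carbon, three bonds along the chain from an amide-type nitrogen. This is the same kind of change as from compound 2 to compound 1, though the place is not the same: there the amine sits two bonds along the chain from the amide-type nitrogen, here three bonds along the chain. Because the earlier step was a 1.3-fold higher number from compound 2 to compound 1 (0.12 log units; within the scatter), a step of similar size is expected, estimated as a 1.2-fold higher number from compound 3 to compound 4 (0.09 log units; within the scatter). Compound 4 is therefore expected to give about 600 nM in this assay, between 300 nM and 1200 nM.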

Compound 4, half-maximal inhibitory concentration: 190 nM
Compound 4: the middle estimate sits 3.2-fold (0.50 log units) above what was measured; measured number below the stated range.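

In this assay, diethylamino in place of dimethylamino gives a 2.6-fold lower number from compound 3 to compound 4 (0.41 log units; beyond the scatter), so the change does not carry over at a fixed size from one core to the other: the same change on two cores in this assay, a 1.3-fold higher number (0.12 log units; within the scatter) from compound 2 to compound 1 and a 2.6-fold lower number (0.41 log units; beyond the scatter) from compound 3 to compound 4, 3.4-fold (0.53 log units) apart, beyond the scatter of two such steps
A step read on the core of compound 2 is therefore a poor guide to the same change on the core of compound 3. This does not show which difference between the two cores sets the gap, and two pairs in one assay give no general rule.

Still open, from the compounds shown here alone, is how the change reads on a core that carries only one of those differences. Also open, going by these compounds, is whether dipropylamino or a longer chain would extend the gain seen on the core of compound 3.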